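Varying the group on the carbonyl carbon of the shared core

A few compounds are considered here, and "the series" means these few. Any claim that something is new, unique, unknown or untested is made for them only; others in the source may bear on it.

Compound 1 `CCCCCC(=O)c1ccc(OCCCN2CCN(C(=O)OC)CC2)cc1` and compound 2 `CCCCCC(=O)c1ccc(OCCCN2CCN(C(=O)c3c[nH]cn3)CC2)cc1` share one core and differ only in the group on a carbonyl carbon. In an assay on isolated protein for binding affinity to histamine H2 receptor (Homo sapiens) (a higher number here means a weaker inhibitor, a lower number a stronger inhibitor), compound 1 gives 12000 nM, and compound 2 gives 19500 nM. The step of a 1.6-fold higher number from compound 1 to compound 2 (0.21 log units; within the scatter) separates nothing. Among the compounds with values here, compound 2 thus stands at one end of the two numbers, with compound 1, its only neighbour, within the scatter of it. Compound 3 `CCCCCC(=O)c1ccc(OCCCN2CCN(C(=O)C3CCC3)CC2)cc1` follows from compound 2 by the change (cyclobutyl in place of 1H-imidazol-4-yl on a carbonyl carbon). Within the data shown here, the single measured step bearing on this position is a 1.6-fold higher number from compound 1 to compound 2 (0.21 log units; within the scatter), which stayed within the scatter, so the one exchange made so far at the carbonyl carbon has not moved this assay beyond its usual spread. The same is expected here: the step of a 1.3-fold lower number from compound 2 to compound 3 (0.11 log units; within the scatter) is expected to stay within the scatter. For compound 3 the estimate in this assay is 15000 nM, with a range from 5000 nM to 45000 nM.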

Compound 3, inhibition constant: 10200 nM
Compound 3: middle estimate off by 1.5-fold (0.17 log units), on the high side; the range from low to high includes it.
By their numbers in this assay, from the lowest: compounds 3, 1 and 2 (each within the scatter of the next).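

Exchanging 1H-imidazol-4-yl for cyclobutyl gives a 1.9-fold lower number from compound 2 to compound 3 (0.28 log units; within the scatter) in this assay, so losing the aromatic ring and its hydrogen-bond donor and acceptor at this carbonyl carbon does not move the number beyond the scatter. Cyclobutyl in place of methoxy gives a 1.2-fold lower number from compound 1 to compound 3 (0.07 log units; within the scatter), which puts all three groups on this carbonyl carbon, methoxy, 1H-imidazol-4-yl and cyclobutyl, within the scatter of one another, although they differ in ring, aromaticity and hydrogen-bond count. No evidence is available to explain this flat result.

Open, on these data alone, is whether an amine, a carboxylic acid or a longer alkyl chain on the same carbonyl carbon would step beyond the scatter in either direction. Also open, as far as these compounds go, is whether any change elsewhere on the shared core would shift these numbers more than the exchanges at this position have.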